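Methoxy in Place of Methyl: From Compound 3 to Compound 4

The source may report more compounds than this note shows. Statements on the series, on what has been measured and on what is new or still open speak of the compounds shown alone.

Of the compounds shown here, three with a shared core have been measured in a functional assay on MDA-MB-231 cells (Homo sapiens) for cytotoxicity, read by sulforhodamine B assay, with a stated time of 48 h; on this read-out higher numbers stand for weaker inhibition of growth and lower numbers for stronger inhibition of growth. Compound 1 `COc1ccc(-c2ccc(C)n2-c2ccc(-c3nc4ccccc4s3)cc2)cc1` gives 3990 nM. For the measured compounds named here, compound 2 `COc1ccc(-c2ccc(C)n2-c2ccc(-c3nc4ccc(F)cc4s3)cc2)cc1` gives 3070 nM, and the only single-site step among the measured compounds, a 1.3-fold lower number from compound 1 to compound 2 (0.11 log units; within the scatter), is thus too small to read as a change. Compound 3 `COc1ccc2nc(-c3ccc(-n4c(C)ccc4-c4ccc(C)cc4)cc3)sc2c1` gives 4010 nM, the highest of the three numbers, yet its gap to compound 1 and its gap to compound 2 both lie within the scatter, so the three values cannot be ordered.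

Compound 4 `COc1ccc(-c2ccc(C)n2-c2ccc(-c3nc4ccc(OC)cc4s3)cc2)cc1` differs from compound 3 by methoxy in place of methyl on an aromatic carbon. Going by the values given here, no measured step bears directly on this exchange: the one recorded step concerns a fluoro for hydrogen exchange and stayed within the scatter, and compounds 1 and 3, which carry methoxy and methyl on different rings of the core, give numbers within the scatter of each other. On this basis compound 4 is expected to land close to compound 3, with the step of a 1.1-fold lower number from compound 3 to compound 4 (0.06 log units; within the scatter) expected to remain within the scatter. The estimate for compound 4 in this assay is 3500 nM, with a range from 1800 nM to 7000 nM.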

Compound 4, concentration for 50% growth inhibition: 4120 nM
For compound 4 the middle estimate is 1.2-fold (0.07 log units) below the measured one; the range from low to high includes it.
By their numbers in this assay, from the lowest: compounds 2, 1, 3 and 4 (each within the scatter of the next).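

Methoxy in place of methyl, on an aromatic carbon para to a large group, makes no readable difference in this assay: the exchange gives a 1.0-fold higher number from compound 3 to compound 4 (0.01 log units; within the scatter), so 4-methylphenyl and 4-methoxyphenyl cannot be told apart on this read-out. The result also extends the picture at the other substituted aromatic carbon of the shared core, where methoxy in place of hydrogen gives a 1.0-fold higher number from compound 1 to compound 4 (0.01 log units; within the scatter) and methoxy in place of fluoro gives a 1.3-fold higher number from compound 2 to compound 4 (0.13 log units; within the scatter), so hydrogen, fluoro and methoxy at that carbon cannot be separated either. Nothing available accounts for this lack of separation.

From the compounds shown here alone, whether an amine, a carboxylic acid or a longer chain in place of the methoxy of the 4-methoxyphenyl group would move the number beyond the scatter remains open. Since every step among these four compounds lies within the scatter, they do not yet show that either site can respond to a change in this assay.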